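The source may report more compounds than this note shows. Statements on the series, on what has been measured and on what is new or still open speak of the compounds shown alone.

Compound 1, `CCCn1c(-c2ccccc2)nc2c(NC3CCCC3)ncnc21`, in an assay on CHO cells for displacement of a labelled ligand from adenosine receptor A3 (Homo sapiens), read by scintillation counting, with a stated time of 3 h (a higher number here means a weaker inhibitor, a lower number a stronger inhibitor), gives 749 nM.
Compound 2, `Cn1c(-c2ccc(C(=O)O)cc2)nc2c(NC3CCCC3)ncnc21`, gives 25700 nM.
Compound 3, `Cn1c(-c2ccccc2Cl)nc2c(NC3CCCC3)ncnc21`, gives 720 nM.

Compound 3 has the lowest number of the three, yet its gap to compound 1 lies within the usual scatter, so the two cannot be told apart; compound 2 stands far higher. Compound 4, `Cn1c(-c2ccccc2)nc2c(NC3CCCC3)ncnc21`, has not yet been measured. It differs from compound 3 in one place: hydrogen in place of chloro on an aromatic carbon. Among the measured compounds shown here, no two measured compounds differ by this change alone, so no measured step shows its effect. A small step is expected, likely none beyond the scatter, because compound 1 with its unsubstituted phenyl gives 749 nM close to compound 3. The step from compound 3 to compound 4 is therefore estimated as a 1.4-fold higher number from compound 3 to compound 4 (0.14 log units; within the scatter). Compound 4 is expected to give 1000 nM, between 350 nM and 3000 nM.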

Compound 4, inhibition constant: 846 nM
Compound 4: the middle estimate sits 1.2-fold (0.07 log units) above what was measured; the range from low to high includes it.
By their numbers in this assay, from the lowest: compounds 3, 1 and 4 (each within the scatter of the next); then compound 2.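

Hydrogen and chloro on this aromatic carbon, ortho to a large group, cannot be told apart, a 1.2-fold higher number from compound 3 to compound 4 (0.07 log units; within the scatter), and the same holds for hydrogen and ethyl on the saturated chain carbon bound to an aromatic nitrogen, a 1.1-fold higher number from compound 1 to compound 4 (0.05 log units; within the scatter). Only carboxy on an aromatic carbon stands apart among these changes, a 30-fold lower number from compound 2 to compound 4 (1.48 log units; beyond the scatter). Nothing measured here explains these steps.

Still open, on these data alone, is whether an amine or a methoxy group on that ortho carbon would behave like chloro. Also open, as far as these compounds go, is whether a chain longer than that of compound 1 would stay within the scatter.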